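A few compounds are considered here, and "the series" means these few. Any claim that something is new, unique, unknown or untested is made for them only; others in the source may bear on it.

Measured compounds:
compound 1 `CCOC(=O)c1c(-c2cccc(OC)c2)[nH]c2cc(F)cc(F)c2c1=O`: > 22000 nM
compound 2 `CCOC(=O)c1c(-c2cccc(Oc3ccccc3)c2)[nH]c2cc(F)cc(F)c2c1=O`: > 22000 nM
compound 3 `CCOC(=O)c1c(-c2cccc(OC)c2)[nH]c2cc(OC)c(OC)cc2c1=O`: > 22000 nM

In an ADME assay on HEK293 cells (Homo sapiens) for cytotoxicity, read by luminescence, with a stated time of 72 h (on this read-out lower numbers stand for an effect already at smaller amounts and higher numbers for an effect only at larger amounts of compound), compound 1 gives only a limit, > 22000 nM. Compound 2 also gives a limit in this assay, > 22000 nM. Compound 3 likewise gives a limit, > 22000 nM. Compound 2 arises from compound 1 by phenyl in place of methyl on an oxygen on an aromatic ring; the step that the two limits leave unreadable from compound 1 to compound 2 cannot be read because both values sit at the limit of > 22000 nM in this assay, at which 3 of the 3 values shown sit. The difference between the cores of compound 1 and compound 3 is not broken down here.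

Compound 4 `CCOC(=O)c1c(-c2cccc(Oc3ccccc3)c2)[nH]c2cc(OC)c(OC)cc2c1=O` differs from compound 3 by phenyl in place of methyl on an oxygen on an aromatic ring, the same change at the same place. For compound 4 the expected step is a step that the limit leaves unreadable from compound 3 to compound 4, since compound 3 itself only reaches the limit > 22000 nM and the earlier step of this change is unreadable. Compound 4 is therefore expected to sit near 30000 nM, between 15000 nM and 80000 nM, most likely again as a limit.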

Compound 4, half-maximal effective concentration: > 22000 nM
Compound 4 was reported as a limit; the forecaster's own chance of this, stated with the estimate: 85%; the middle value lies beyond the limit too.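

Compound 3 and compound 4 both give only a limit, so no step between them can be read: the limit of > 22000 nM in this assay, at which 4 of the 4 values shown sit.

The compounds shown leave open at what concentration any of them would become cytotoxic, and whether methoxy to phenoxy alters that concentration.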